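The source may hold more compounds than are shown below. What is called first, only, known or untested is meant among the compounds shown, and "the series" means these compounds.

Working notes on the series. The shared core, shown in compound 1 `CCc1nc(-c2ccc(Cl)cc2Cl)c(CC)nc1NC(COC)COC`, carries a dichlorophenyl ring and an amino substituent that is varied. In an assay on IMR-32 cells for displacement of a labelled ligand from corticotropin-releasing factor receptor 1 (Homo sapiens), read by scintillation counting, with a stated time of 2 h (a higher number here means a weaker inhibitor, a lower number a stronger inhibitor), compound 1 gives 224 nM, the highest number of the three measured. Compound 2 `CCC(CC)Nc1nc(C)c(-c2ccc(Cl)cc2Cl)nc1C` gives 27 nM in this assay, and compound 3 `CCc1nc(-c2ccc(OC(F)(F)F)cc2OC)c(OC)nc1NC(CC)CC` gives 6.1 nM, both well beyond the scatter from compound 1. Compound 4 `CCc1nc(-c2ccc(Cl)cc2Cl)c(CC)nc1NC(C)CN(C)C` has not been measured; it differs from compound 1 by 1-((dimethylamino)methyl)ethyl in place of 2-methoxy-1-(methoxymethyl)ethyl on a nitrogen on an aromatic ring. Going by the values given here, no measured pair shows this change, so its direction is an estimate only; a drop in the number is expected, modest in size, with the step of a 2.0-fold lower number from compound 1 to compound 4 (0.31 log units; beyond the scatter). Compound 4 is therefore estimated at 110 nM, with a range from 30 nM to 450 nM.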

Compound 4, inhibition constant: 489 nM
For compound 4 the middle estimate is 4.4-fold (0.65 log units) below the measured one; the measured number lies above the stated range.
By their numbers in this assay, from the lowest: compound 3; then compound 2; then compound 1; then compound 4.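

Going by these compounds alone, on a nitrogen on an aromatic ring, the change to 1-((dimethylamino)methyl)ethyl from 2-methoxy-1-(methoxymethyl)ethyl gives in this assay a 2.2-fold higher number from compound 1 to compound 4 (0.34 log units; beyond the scatter) as the only one-place comparison. It shows that this amino substituent alters the number on the core of compound 1, and that this exchange raises it rather than lowers it. Nothing at hand accounts for the step.

Still open, on these data alone, is how a primary amine or a carboxylic acid on this chain would read on the same core. Also open, as far as these compounds go, is whether the same exchange would give a similar step on the core of compound 2 or compound 3.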